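One Fluorine Fewer: Trifluoromethyl to Difluoromethyl

The source may report more compounds than this note shows. Statements on the series, on what has been measured and on what is new or still open speak of the compounds shown alone.

Measured so far in an assay on HEK293 cells for inhibition of sodium channel protein type 9 subunit alpha (Mus musculus), read by patch clamp; a lower number here means a stronger inhibitor, a higher number a weaker inhibitor:
- compound 1, `CC(C)COc1ncc(-c2cn(C)c3cc(C(=O)NS(C)(=O)=O)ccc23)cc1Cl`, gives 35 nM
- compound 2, `Cn1cc(-c2ccc(C(F)(F)F)cc2)c2cc(F)c(C(=O)NS(=O)(=O)C3CC3)cc21`, gives 27 nM
- compound 3, `CC(C)COc1ncc(-c2cn(C)c3cc(C(=O)NS(=O)(=O)C4CC4)c(F)cc23)cc1Cl`, gives 10 nM

Compound 2 holds the second highest of these three numbers. Its nearest neighbour is compound 1, whose value lies within the usual scatter of compound 2, so the two cannot be told apart. Compound 3 stands furthest away with a lower number, and that gap lies beyond the scatter.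

Compound 4, `Cn1cc(-c2ccc(C(F)F)cc2)c2cc(F)c(C(=O)NS(=O)(=O)C3CC3)cc21`, has not yet been measured. It differs from compound 2 in one place: hydrogen in place of fluoro on a saturated chain carbon bound to an aromatic carbon and two fluorine atoms. Every other part of the molecule is kept.

Among the compounds with values here, no pair of measured compounds shows this exact change, so the size of the step must be estimated from the change itself. Removing a single fluorine from a saturated chain carbon at the far end of the molecule is a small alteration, and the expected step is a 1.4-fold higher number from compound 2 to compound 4 (0.15 log units; within the scatter), in the direction of a slightly higher number, though not clearly beyond the scatter. Compound 4 is therefore expected to give 38 nM in this assay, with a plausible range from 15 nM to 95 nM.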

Compound 4, half-maximal inhibitory concentration: 231 nM
The estimate for compound 4 lay 6.1-fold (0.78 log units) below the measured number, outside the stated range (above it).
By their numbers in this assay, from the lowest: compound 3; then compounds 2 and 1 (each within the scatter of the next); then compound 4.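

In this assay, replacing one fluorine of the trifluoromethyl group with hydrogen gives an 8.6-fold higher number from compound 2 to compound 4 (0.93 log units; beyond the scatter), a clear weakening of inhibition. Within the data shown here, the earlier compounds offered no pair differing in one place, so this is the first direct reading of a single change, and it shows that this place on the 4-(trifluoromethyl)phenyl group is sensitive: one fluorine leaving, with no ring, charge, hydrogen-bond donor or acceptor involved, moves the number well beyond the scatter. No measurement here accounts for a step of this size, so its cause remains unknown.

On these data alone, whether the number would climb further with a monofluoromethyl or methyl group at this place remains open. So does whether a nitrile or a single chlorine atom there would bring it back towards that of compound 2.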